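The source may hold more compounds than are shown below. What is called first, only, known or untested is meant among the compounds shown, and "the series" means these compounds.

Three compounds share a core and differ only in the group carried on one aromatic carbon. Compound 1 `CCCCN(C)c1cc(C(F)(F)F)ccc1CNC(=O)C(C)c1ccc(NS(C)(=O)=O)c(F)c1` gives 1.2 nM in an assay on CHO cells for antagonist activity at transient receptor potential cation channel subfamily V member 1 (Homo sapiens), read by FLIPR; on this read-out higher numbers stand for weaker inhibition and lower numbers for stronger inhibition. Compound 2 `CC(C)CCOc1cc(C(F)(F)F)ccc1CNC(=O)C(C)c1ccc(NS(C)(=O)=O)c(F)c1` gives 0.5 nM, and compound 3 `CC(C(=O)NCc1ccc(C(F)(F)F)cc1OCc1ccc(F)cc1)c1ccc(NS(C)(=O)=O)c(F)c1` gives 0.5 nM. Compound 3 thus stands level with compound 2 at the digits shown, the two together being the lowest of the three numbers, with no change at the digits printed from compound 2 to compound 3 (within the scatter) and a 2.4-fold lower number from compound 1 to compound 3 (0.38 log units; beyond the scatter).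

Compound 4 `CC(C(=O)NCc1ccc(C(F)(F)F)cc1SCCCO)c1ccc(NS(C)(=O)=O)c(F)c1` is made from compound 3 by one change: (3-hydroxypropyl)sulfanyl in place of (4-fluorobenzyl)oxy on an aromatic carbon. Within the data shown here, no measured step covers this kind of exchange. The closest guide is that the two groups tried on this carbon, isopentyloxy and (4-fluorobenzyl)oxy, gave the same number, while butyl(methyl)amino gave a 2.4-fold lower number from compound 1 to compound 2 (0.38 log units; beyond the scatter) in the other direction. The new group is smaller and adds a hydrogen-bond donor, so a modest rise in the number is expected, about a 4.0-fold higher number from compound 3 to compound 4 (0.60 log units; beyond the scatter). Compound 4 is therefore estimated at 2 nM, between 0.5 nM and 8 nM.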

Compound 4, inhibition constant: "not active" (no number reported)
No number was reported for compound 4, and the estimate cannot be compared.
By their numbers in this assay, from the lowest: compounds 2 and 3 (each within the scatter of the next); then compound 1.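

Among these compounds, compound 4 is reported only as "not active" in this assay, with no number, so no step from compound 3 to compound 4 can be read. Nothing shown explains this result. The compounds shown leave open which part of the exchange, the sulfur, the hydroxy group or the lost ring, goes with it.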